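The source may hold more compounds than are shown below. What is called first, only, known or untested is meant among the compounds shown, and "the series" means these compounds.

Three compounds sharing the core of compound 1 `CCCc1nc(-c2ccccc2)c(CNCCN2CCN(c3cccc(C(F)(F)F)c3)CC2)o1` have been measured in an assay on HEK293 cells for inhibition of Voltage-dependent T-type calcium channel subunit alpha-1G (Homo sapiens), read by fluorescence, tested at 10 uM; a higher number here means more inhibition at the concentration tested (going by the name of the read-out), a lower number less inhibition. Compound 1 gives 56.3%. Compound 2 `CCCc1nc(-c2ccccc2)c(CNCCCN2CCN(c3cccc(F)c3)CC2)o1` gives 68.9%, and compound 3 `CCCc1nc(-c2ccccc2)c(CNCCCN2CCN(c3ccccc3Cl)CC2)o1` gives 64.7%. Compound 1 holds the lowest of the three numbers, though its gap to compound 3 lies within the scatter, while compound 2 stands beyond it. Among the measured compounds shown here, the only single-point step among the measured compounds, a number 4.2 percentage points lower from compound 2 to compound 3 (within the scatter), stays within the scatter.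

Compound 4 `CCCc1nc(-c2ccccc2)c(CNCCN2CCN(c3ccccc3)CC2)o1` has not yet been measured. It differs from compound 1 by hydrogen in place of trifluoromethyl on an aromatic carbon. For the measured compounds named here, no measured step removes a group from this ring altogether; the one measured change on this ring, swapping one substituted phenyl for another, left the read-out within the scatter, and compound 1 and compound 2 differ in two places at once, so their values alone cannot separate the two changes. On that footing compound 4 is expected to stay close to compound 1, with a number 4.3 percentage points lower from compound 1 to compound 4 (within the scatter) not beyond the scatter. The estimate for compound 4 is 52%, lying between 34% and 70%.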

Compound 4, a percentage reported as inhibition, at one concentration (the size of the read-out at that concentration, not a potency): 54.3%
The estimate for compound 4 lay 2.3 percentage points below the measured number; measured number inside the range.
By their numbers in this assay, from the lowest: compounds 4, 1, 3 and 2 (each within the scatter of the next, the first and the last beyond it).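

In this assay, among the compounds shown here, the change from 3-(trifluoromethyl)phenyl to phenyl gives a number 2 percentage points lower from compound 1 to compound 4 (within the scatter) and is the first measured step that removes a group from this ring altogether, where the earlier step only swapped one substituted phenyl for another. With the chain of compound 1 in place, the read-out at this position therefore does not separate trifluoromethyl from hydrogen beyond the scatter. Nothing available accounts for this result.

Going by these compounds, it remains open whether a different group at this position, such as a methoxy group, an amine or a carboxylic acid, would separate from hydrogen in this read-out. On these data alone, it is also open whether removing the group would read the same on the longer chain carried by compound 2 and compound 3.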